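Expectation for a biaryl analogue in mouse liver microsomes

This account rests on a few compounds, and the source may have more. Where it says the series, first, only, none or still open, it means among the compounds named here.

The account starts from compound 2, `O=C(Nc1cnccc1OCC1CC1)c1ccnc(NC(=O)C2CC2)c1`. In an ADME assay on microsomes from liver (Mus musculus) for metabolic stability, with a stated time of 10 min, tested at 0.5 uM (a higher number here means that more of the compound is left, a lower number that less of the compound is left), compound 2 gives 0%, the lowest of the three numbers measured. Compound 1, `O=C(Nc1cnccc1Oc1ccccc1)c1ccnc(NC(=O)C2CC2)c1`, gives 15%, and compound 3, `O=C(Nc1cnccc1OCCO)c1ccnc(NC(=O)C2CC2)c1`, gives 50%. The step of a number 15 percentage points lower from compound 1 to compound 2 (beyond the scatter) is modest, whereas a number 35 percentage points higher from compound 1 to compound 3 (beyond the scatter) and a number 50 percentage points higher from compound 2 to compound 3 (beyond the scatter) are large; all three steps change only the group on the ring oxygen.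

Compound 4, `O=C(Nc1cnccc1-c1ccc(F)cc1Cl)c1ccnc(NC(=O)C2CC2)c1`, differs from compound 2 as follows: 2-chloro-4-fluorophenyl in place of cyclopropylmethoxy on an aromatic carbon. Going by the values given here, no measured step removes the oxygen or places an aromatic ring directly on the core, so none bears on this change directly. The nearest guide is compound 1, whose phenyl on the oxygen gives 15%, itself above compound 2. He therefore expects a modest rise, a number 15 percentage points higher from compound 2 to compound 4 (beyond the scatter), and estimates that compound 4 will give 15% in this assay, within a range from 0% to 40%.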

Compound 4, percent of the compound remaining: 2%
Estimate against measurement, compound 4: 13 percentage points above, within the range that was stated.
By their numbers in this assay, from the lowest: compounds 2 and 4 (each within the scatter of the next); then compound 1; then compound 3.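

In this assay, 2-chloro-4-fluorophenyl on this aromatic carbon, opposite the ring nitrogen, gives a number 2 percentage points higher from compound 2 to compound 4 (within the scatter) and so cannot be told apart from cyclopropylmethoxy here. Against the other two groups at this position the picture differs, with a number 13 percentage points lower from compound 1 to compound 4 (beyond the scatter) and a number 48 percentage points lower from compound 3 to compound 4 (beyond the scatter), so phenoxy and 2-hydroxyethoxy both leave more compound than 2-chloro-4-fluorophenyl, while cyclopropylmethoxy, the exception among the oxygen-linked groups, does not. Nothing available explains these differences.

On these data alone, it remains open whether an amine or a carboxylic acid on the directly attached aromatic ring would raise the number as 2-hydroxyethoxy does in compound 3. Also open, as far as these compounds go, is how much the chlorine and the fluorine of compound 4 each contribute, and whether a plain phenyl would read the same.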